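Swapping Methoxy for Fluoro on the Shared Core

A few compounds are considered here, and "the series" means these few. Any claim that something is new, unique, unknown or untested is made for them only; others in the source may bear on it.

Compound 1 `COc1ccc2c(C3CC(c4ccncc4)=NO3)c[nH]c2c1` gives 3500 nM in a functional assay on LNCaP C4-2 cells (Homo sapiens) for inhibition, read by MTT assay, with a stated time of 48 h; on this read-out higher numbers stand for weaker inhibition and lower numbers for stronger inhibition. Compound 2 `COc1ccc2c(C3CC(c4ccncc4)=NO3)cn(Cc3ccc(Cl)cc3)c2c1` is reported in this assay only as a limit, > 100000 nM, not as a measured number.

Within the data shown here, compound 1 thus stands as the only compound with a real number in this assay; the one other result is a limit. Among the measured compounds shown here, the single measured step, an at least 28-fold higher number from compound 1 to compound 2 (1.45 log units; beyond the scatter), is large, and it happens on the nitrogen of the shared core, where compound 2 sits at the limit of > 100000 nM in this assay, at which 1 of the 2 values shown sits. The step toward compound 3 `Fc1ccc2c(C3CC(c4ccncc4)=NO3)c[nH]c2c1` is of a different kind: fluoro in place of methoxy on an aromatic carbon. No measured step touches this aromatic carbon, so the step on the nitrogen gives no direct guide, and there is nothing to point to as a cause either way. Given that silence, the expectation for compound 3 is a step of about a 1.4-fold higher number from compound 1 to compound 3 (0.15 log units; within the scatter) in this assay, which is not expected to lie clearly beyond the usual scatter. Compound 3 is therefore estimated at 5000 nM, with a plausible range from 1500 nM to 20000 nM.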

Compound 3, half-maximal inhibitory concentration: 8000 nM
Beside the measured number, compound 3's estimate is 1.6-fold (0.20 log units) below it; the measured number falls inside the stated range.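

The aromatic carbon that holds the methoxy group in the shared core now has a measured step of its own: fluoro in place of methoxy gives a 2.3-fold higher number from compound 1 to compound 3 (0.36 log units; beyond the scatter) in this assay and so means somewhat weaker inhibition. The step is modest, and compound 3 keeps a real measured number, unlike compound 2, whose result is only a limit, so this carbon shows that a change on the core can shift the read-out without ending at a limit. Nothing shown here explains why the swap weakens inhibition, since the only fact on record concerns compound 2 and not this aromatic carbon.

As far as these compounds go, with only methoxy and fluoro compared at this carbon, it remains open whether an amine, a hydroxyl group or a longer chain such as ethoxy would give a number nearer to that of compound 1 or further from it. From the compounds shown here alone, it is also open how the fluoro group would behave on a core that carries the 4-chlorobenzyl group on the nitrogen.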